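A Methyl on the Benzyl Ring of Compound 3

A few compounds are considered here, and "the series" means these few. Any claim that something is new, unique, unknown or untested is made for them only; others in the source may bear on it.

Compound 1, `Cc1nc(Cc2ccccc2)c2ncnc(O)n12`, gives 263000 nM in a functional assay on CCRF-CEM cells (Homo sapiens) for cytotoxicity; a lower number here means that less compound is tolerated, a higher number that more compound is tolerated.
Compound 2, `Cc1nc(C)n2c(S)ncnc12`, reaches only a limit of the assay, > 694000 nM.
Compound 3, `Cc1nc(C)n2c1NC(SCc1ccccc1)NC2=O`, gives 266000 nM in this assay.

In this assay compound 3 stands alongside compound 1, the two numbers lying within the scatter of one another. Compound 2 is reported only as a limit of the assay. Compound 4, `Cc1ccc(CSC2NC(=O)n3c(C)nc(C)c3N2)cc1`, differs from compound 3 by methyl in place of hydrogen on an aromatic carbon. Within the data shown here, no measured pair shows this change, so its effect is open; such a small addition is expected to give no step beyond the scatter in this assay. Compound 4 is therefore expected near 250000 nM, between 100000 nM and 650000 nM. The expected step is a 1.1-fold lower number from compound 3 to compound 4 (0.03 log units; within the scatter).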

Compound 4, half-maximal cytotoxic concentration: 88800 nM
Beside the measured number, compound 4's estimate is 2.8-fold (0.45 log units) above it, and the stated range ends above it.
By their numbers in this assay, from the lowest: compound 4; then compounds 1 and 3 (each within the scatter of the next). At a limit, above all of these: compound 2.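

In this assay, among these compounds, the change from phenyl to 4-methylphenyl gives a 3.0-fold lower number from compound 3 to compound 4 (0.48 log units; beyond the scatter) and is the first step that can be read. It shows that a single methyl on this aromatic carbon, para to a large group, is enough to lower the tolerated concentration. No measurement shown bears on why the number moves. The compounds shown leave open whether an ethyl, a methoxy or a chlorine in the same place would move the number the same way, and whether methyl would do so elsewhere on the ring.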